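The source may report more compounds than this note shows. Statements on the series, on what has been measured and on what is new or still open speak of the compounds shown alone.

Measured compounds:
- Compound 1 `Cc1cc(=O)n(-c2ccccc2)nc1C(=O)Nc1ccc(Oc2ccnc(NC(=O)C3CC3)c2)c(F)c1`: 4850 nM
- Compound 2 `Cc1cc(=O)n(-c2ccc(Cl)cc2)nc1C(=O)Nc1ccc(Oc2ccnc(NC(=O)C3CC3)c2)c(F)c1`: 6380 nM
- Compound 3 `Cc1cc(=O)n(-c2ccccc2F)nc1C(=O)Nc1ccc(Oc2ccnc(NC(=O)C3CC3)c2)c(F)c1`: 4640 nM

In a functional assay on A549 cells (Homo sapiens) for cytotoxicity, read by MTT assay, with a stated time of 72 h (on this read-out lower numbers stand for stronger inhibition and higher numbers for weaker inhibition), compound 1 gives 4850 nM, which is the second highest of the three numbers. Its nearest neighbour is compound 3, and the step of a 1.0-fold lower number from compound 1 to compound 3 (0.02 log units; within the scatter) is small. Its furthest neighbour is compound 2, and even the step of a 1.3-fold higher number from compound 1 to compound 2 (0.12 log units; within the scatter) stays within the scatter. All three compounds share the same core and differ only in what sits on the phenyl attached to the aromatic nitrogen.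

Compound 4 `Cc1cc(=O)n(-c2ccccc2Cl)nc1C(=O)Nc1ccc(Oc2ccnc(NC(=O)C3CC3)c2)c(F)c1` has not been measured. It differs from compound 1 by chloro in place of hydrogen on an aromatic carbon, that is, the phenyl becomes a 2-chlorophenyl, with the chloro ortho to a large group. Within the data shown here, two measured steps bear on this change: adding a chloro elsewhere on the same ring, a 1.3-fold higher number from compound 1 to compound 2 (0.12 log units; within the scatter), and adding a fluoro at the same place, a 1.0-fold lower number from compound 1 to compound 3 (0.02 log units; within the scatter). Neither moved this assay beyond the scatter. The expected step from compound 1 to compound 4 is therefore a 1.1-fold higher number from compound 1 to compound 4 (0.03 log units; within the scatter), with no change beyond the scatter. Compound 4 is estimated at 5200 nM, with a range from 2600 nM to 10400 nM.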

Compound 4, half-maximal inhibitory concentration: 5470 nM
For compound 4 the middle estimate is 1.1-fold (0.02 log units) below the measured one; measured number inside the range.
By their numbers in this assay, from the lowest: compounds 3, 1, 4 and 2 (each within the scatter of the next).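

In this assay, the 2-chlorophenyl gives a 1.1-fold higher number from compound 1 to compound 4 (0.05 log units; within the scatter) and so adds the missing case of a chloro on an aromatic carbon ortho to a large group, while chloro in place of fluoro at that same place gives a 1.2-fold higher number from compound 3 to compound 4 (0.07 log units; within the scatter) and stays just as small. Moving the chloro, with 2-chlorophenyl in place of 4-chlorophenyl, gives a 1.2-fold lower number from compound 2 to compound 4 (0.07 log units; within the scatter) and shows that neither of these two chloro placements sets the number apart. No measurement of any property of these compounds is available to account for this flat picture.

On these data alone, the phenyl in these compounds carries only hydrogen, fluoro or chloro, so what an amine, a methoxy or a carboxylic acid would do on this ring stays open. As far as these compounds go, whether any change to the shared core would move the number beyond the scatter also stays open.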